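A few compounds are considered here, and "the series" means these few. Any claim that something is new, unique, unknown or untested is made for them only; others in the source may bear on it.

Compound 1 `O=C(Nc1ccc(-c2noc(-c3cccc(NS(=O)(=O)c4ccc(C(F)(F)F)cc4)c3)n2)c(Cl)c1)c1cccnc1` was tested in a functional assay on MDA-MB-231 cells (Homo sapiens) for antiproliferative activity, read by MTT assay, with a stated time of 72 h (on this read-out higher numbers stand for weaker inhibition and lower numbers for stronger inhibition), and gave only a limit, > 10000 nM, so the read-out shows no number for it. Compound 2 `COc1cccc(S(=O)(=O)Nc2cccc(-c3nc(-c4ccc(NC(=O)c5cccnc5)cc4Cl)no3)c2)c1` likewise gave only the limit > 10000 nM in this assay. Compound 3 `CC(=O)Nc1ccc(S(=O)(=O)Nc2cccc(-c3nc(-c4ccc(NC(=O)c5cccnc5)cc4Cl)no3)c2)cc1Cl` also stopped at the limit > 10000 nM in this assay. Because of this, (the limit of > 10000 nM in this assay, at which 3 of the 3 values shown sit), the three measured steps cannot be sized: a step that the two limits leave unreadable from compound 1 to compound 2, a step that the two limits leave unreadable from compound 1 to compound 3 and a step that the two limits leave unreadable from compound 2 to compound 3. All three change only the group on the sulfonyl sulfur, and none of them moved any compound to a readable number.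

Compound 4 `O=C(Nc1ccc(-c2noc(-c3cccc(NS(=O)(=O)c4ccc(NC(=O)N5CCCCC5)cc4)c3)n2)c(Cl)c1)c1cccnc1` follows the same pattern of change: ((piperidin-1-yl)carbonyl)amino in place of trifluoromethyl on an aromatic carbon. The three measured steps bear on it directly, since each of them also swapped the group on the sulfonyl sulfur, yet none of them gave a readable size. No step beyond the scatter can therefore be expected in this assay, and compound 4 is estimated to stay at or near the limit as well, with a step that the limit leaves unreadable from compound 1 to compound 4. The expected value for compound 4 is 15000 nM, in a range from 5000 nM to 50000 nM.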

Compound 4, half-maximal inhibitory concentration: > 10000 nM
Compound 4 was reported as a limit; the forecaster's own chance of this, stated with the estimate: 80%; the middle value lies beyond the limit too.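

Compound 4, like compound 1, ends at a limit and not a number in this assay, so no size can be read for the change between them: the limit of > 10000 nM in this assay, at which 4 of the 4 values shown sit. The compounds shown leave open which group on the sulfonyl sulfur, if any, would give a readable number in this assay.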